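This account rests on a few compounds, and the source may have more. Where it says the series, first, only, none or still open, it means among the compounds named here.

Measured compounds:
Compound 1, `CCOc1cc(C(Nc2ccc3c(N)nccc3c2)C(=O)NS(=O)(=O)c2cccc(C(N)=O)c2)ccc1OC(C)C`, in an assay on isolated protein for inhibition of Trypsin (Homo sapiens); on this read-out lower numbers stand for stronger inhibition and higher numbers for weaker inhibition: > 5000 nM
Compound 2, `CCOc1cc(C(Nc2ccc3c(N)nccc3c2)C(=O)NS(=O)(=O)c2cccc(CO)c2)ccc1OC(C)C`, in this assay: > 5000 nM

In this assay compound 1 gives only a limit, > 5000 nM, and no number. Compound 2 likewise gives only a limit in this assay, > 5000 nM. The step from compound 1 to compound 2, a step that the two limits leave unreadable from compound 1 to compound 2, therefore has no readable size. The whole of what the two measurements show is the limit of > 5000 nM in this assay, at which 2 of the 2 values shown sit, so compound 2 stands at that limit and nowhere more precise.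

Compound 3, `CCOc1cc(C(Nc2ccc3c(N)nccc3c2)C(=O)NS(=O)(=O)c2cccc(N)c2)ccc1OC(C)C`, differs from compound 2 by amino in place of hydroxymethyl on an aromatic carbon. For the measured compounds named here, no measured step with a readable size bears on this change; the only related step, the one from compound 1 to compound 2, is hidden behind two limits. With nothing to set a direction, the expectation for compound 3 is that it stays near the limit where compound 2 sits.

Compound 3 is estimated to give 8000 nM in this assay. The expected range for compound 3 runs from 2500 nM to 30000 nM. This estimate means an expected step that the limit leaves unreadable from compound 2 to compound 3, with a strong chance that only a limit is reported again.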

Compound 3, inhibition constant: > 5000 nM
Compound 3: no number, only a limit (the forecaster's own chance of this, stated with the estimate: 80%); the middle value does not contradict the limit.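

In this assay, for the compounds shown here, compound 3 again gives only a limit, so no step to it from compound 2 or compound 1 can be read, and all three compounds stand together: the limit of > 5000 nM in this assay, at which 3 of the 3 values shown sit.

The compounds shown leave open how strongly each one inhibits, and whether carbamoyl, hydroxymethyl and amino differ at all on this read-out.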